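Methyl for Phenyl on a Glycine Transporter Inhibitor Scaffold

The source may report more compounds than this note shows. Statements on the series, on what has been measured and on what is new or still open speak of the compounds shown alone.

Compound 2 `NC(C/C=C(\c1ccc(-c2ccccc2)cc1)c1ccc(F)cc1F)C(=O)O` has been tested in a functional assay for inhibition of sodium- and chloride-dependent glycine transporter 1 (Rattus norvegicus), with a stated time of 30 min, in the presence of a further agent that is not named here; on this read-out lower numbers stand for stronger inhibition and higher numbers for weaker inhibition. In this assay compound 2 gives > 10000 nM, which is a limit of the assay rather than a number. Compound 1 `CC(C)(C)c1ccc(/C(=C\CC(N)C(=O)O)c2ccc(F)cc2F)cc1` in this assay gives > 10000 nM, again a limit. The step that the two limits leave unreadable from compound 1 to compound 2 cannot be read because the limit of > 10000 nM in this assay, at which 2 of the 2 values shown sit, leaves both ends undefined. Compound 3 `Cc1ccc(/C(=C\CC(N)C(=O)O)c2ccc(F)cc2F)cc1` differs from compound 2 by methyl in place of phenyl on an aromatic carbon. Within the data shown here, no measured step bears on this change in a readable way, so the size and direction of any effect in this assay remain open, and the only guide is that both measured compounds sit at the limit. The step expected from compound 2 to compound 3 is therefore a step that the limit leaves unreadable from compound 2 to compound 3, with no supported direction. Compound 3 is estimated at 20000 nM in this assay, within a range of 4000 nM to 100000 nM, and a further limit rather than a number is expected to be the most likely outcome.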

Compound 3, half-maximal inhibitory concentration: 9560 nM
Estimate against measurement, compound 3: 2.1-fold (0.32 log units) above; measured number inside the range.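

In this assay compound 3 gives 9560 nM, the only value of the three shown at this position, on an aromatic carbon para to a large group, that is a number rather than a limit. Methyl in place of phenyl reads as an at least 1.0-fold lower number from compound 2 to compound 3 (0.01 log units; that floor lies within the scatter), and methyl in place of tert-butyl reads as an at least 1.0-fold lower number from compound 1 to compound 3 (0.01 log units; that floor lies within the scatter). Both steps are floors that show no change beyond the scatter, and their true size stays undefined because the other two compounds sit at a limit: the limit of > 10000 nM in this assay, at which 2 of the 3 values shown sit.

On these data alone, it remains open how far compound 3 really lies from compound 1 and compound 2. As far as these compounds go, it is also open how the read-out responds at this position to a hydrogen, a chlorine or a methoxy group in place of the methyl.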